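Sulfonyl aryl swap in the sulfonamide series

This account rests on a few compounds, and the source may have more. Where it says the series, first, only, none or still open, it means among the compounds named here.

Measured so far:
compound 1 `O=S(=O)(Nc1ccc2oc(-c3ccccc3)nc2c1)c1ccc(Cl)c(Cl)c1` gives > 100000 nM in an assay on cells for inhibition of HSP60/HSP10 (Homo sapiens), with a stated time of 60 min; on this read-out higher numbers stand for weaker inhibition and lower numbers for stronger inhibition.
compound 2 `O=S(=O)(Nc1ccc(-c2nc3ccccc3o2)cc1)c1ccc(Cl)s1` gives 31000 nM.
compound 3 `O=S(=O)(Nc1ccc2oc(-c3ccccc3)nc2c1)c1cccc(O)c1` gives 76000 nM.

For compound 1 the value in this assay is a limit, not a number. Among the two numbers shown, compound 2 stands lowest; its nearest neighbour is compound 3, and the gap between them lies beyond the scatter.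

Compound 4 `O=S(=O)(Nc1ccc(-c2nc3ccccc3o2)cc1)c1ccc(O)cc1` differs from compound 2 in one place: 4-hydroxyphenyl in place of 5-chlorothiophen-2-yl on a sulfonyl sulfur.

Among the compounds with values here, only one measured step bears on a hydroxyphenyl entering on the sulfonyl sulfur, an at least 1.3-fold lower number from compound 1 to compound 3 (0.11 log units; that floor lies within the scatter), and its size is bounded only by the limit of > 100000 nM in this assay, at which 1 of the 3 values shown sits, so it sets a floor rather than a size. The hydroxyphenyl compounds shown, compound 3 at 76000 nM, sit in the same weak region as compound 2 at 31000 nM. No step beyond the scatter is therefore expected in either direction, with a wide range to reflect how little is fixed.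

Compound 4 is expected near 50000 nM, from 15000 nM to 200000 nM. The step expected in this assay is a 1.6-fold higher number from compound 2 to compound 4 (0.21 log units; within the scatter).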

Compound 4, half-maximal inhibitory concentration: 78000 nM
Compound 4: middle estimate off by 1.6-fold (0.19 log units), on the low side, and the stated range covers the measured number.
By their numbers in this assay, from the lowest: compound 2; then compounds 3 and 4 (each within the scatter of the next). At a limit, above all of these: compound 1.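

With 4-hydroxyphenyl in place of 5-chlorothiophen-2-yl on a sulfonyl sulfur, this assay shows a 2.5-fold higher number from compound 2 to compound 4 (0.40 log units; beyond the scatter), a modest step that gives this position its first change of measured size. On this core, therefore, the group on the sulfonyl sulfur does move the read-out beyond the scatter, and the direction favours 5-chlorothiophen-2-yl over 4-hydroxyphenyl, though this rests on one pair and both compounds remain weak. The earlier step on this sulfur starts from compound 1, whose value is a limit and gives no size: the limit of > 100000 nM in this assay, at which 1 of the 4 values shown sits.

The change swaps a five-membered aromatic ring carrying chlorine for a six-membered aromatic ring of carbon carrying hydroxy, so the compounds shown cannot separate the effect of the ring from that of its substituent; a plain phenyl, a 5-methylthiophen-2-yl, or a 4-chlorophenyl on the same sulfur would be needed to divide the step. From the compounds shown here alone, it also remains open whether any group at this position reaches a much lower number, for example a phenyl bearing a carboxylic acid or an amine, and whether the step holds on the core of compound 1.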